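Moving the Ring Nitrogen Once More in Compound 4

This account rests on a few compounds, and the source may have more. Where it says the series, first, only, none or still open, it means among the compounds named here.

Three compounds share one core and differ only in the aromatic ring attached through an oxygen on a saturated carbon. Compound 1 `O=C1c2cc(COc3ccccc3F)nn2CCN1c1ccc(F)cc1` gives 66% in a functional assay on HEK293 cells for positive allosteric modulation of metabotropic glutamate receptor 5 (Homo sapiens), read by calcium flux; a lower number here means a smaller maximal response, a higher number a larger maximal response. Compound 2 `O=C1c2cc(COc3ccccn3)nn2CCN1c1ccc(F)cc1` gives 68%, and compound 3 `O=C1c2cc(COc3cccnc3)nn2CCN1c1ccc(F)cc1` gives 69%. The steps between them are all small: a number 2 percentage points higher from compound 1 to compound 2 (within the scatter), a number 3 percentage points higher from compound 1 to compound 3 (within the scatter) and a number 1 percentage points higher from compound 2 to compound 3 (within the scatter). Compound 3 therefore holds the highest of the three numbers, but its gaps to compound 2 and to compound 1 are within the scatter, so the three cannot be told apart on this assay.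

Compound 4 `O=C1c2cc(COc3ccncc3)nn2CCN1c1ccc(F)cc1` takes the same route: pyridin-4-yl in place of pyridin-3-yl on an oxygen on a saturated carbon. For the measured compounds named here, the steps that bear on it, pyridin-2-yl to pyridin-3-yl and 2-fluorophenyl to either pyridyl, all stayed within the scatter, so no step beyond the scatter is expected here either. The estimated change is a number 1 percentage points lower from compound 3 to compound 4 (within the scatter). Compound 4 is therefore expected to give about 68%, within a range from 58% to 78%, in this assay.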

Compound 4, largest response reached (Emax), in percent of the reference or control that the assay uses: 69%
Compound 4: the middle estimate sits 1 percentage points below what was measured; the measured number falls inside the stated range.
By their numbers in this assay, from the lowest: compounds 1, 2, 3 and 4 (each within the scatter of the next).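

With pyridin-4-yl in place, the ring nitrogen has now been tried in all three pyridyl forms on this oxygen, and in this assay the last change gives no change at the digits printed from compound 3 to compound 4 (within the scatter) and so adds nothing measurable. The wider comparisons agree, with a number 1 percentage points higher from compound 2 to compound 4 (within the scatter) against the other pyridyl form and a number 3 percentage points higher from compound 1 to compound 4 (within the scatter) against the 2-fluorophenyl ring, so at this position the maximal response does not tell pyridin-2-yl, pyridin-3-yl, pyridin-4-yl and 2-fluorophenyl apart. No measurement here explains why these four compounds lie so close together.

Every group shown on this oxygen is a six-membered aromatic ring, so the compounds leave open what a saturated ring such as piperidin-4-yl or a plain butyl chain would do. They also leave open whether a change at another part of the shared core would move the maximal response further.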